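This account rests on a few compounds, and the source may have more. Where it says the series, first, only, none or still open, it means among the compounds named here.

Working notes on the series.

Compound 1 `CNC(=O)c1cc(C(=O)NC2CCOCC2)n([C@@H](C)c2ccccc2)n1` in an ADME assay for permeability (on this read-out higher numbers stand for higher permeability and lower numbers for lower permeability), gives 270 nm/s. Compound 2 `CNC(=O)c1cc(C(=O)N[C@H]2CC[C@H](O)CC2)n([C@@H](C)c2ccccc2)n1` gives 80 nm/s, and compound 3 `CNC(=O)c1cc(C(=O)N[C@H]2[C@@H]3C[C@@H](O)C[C@@H]32)n([C@@H](C)c2ccccc2)n1` gives 61 nm/s. Compound 3 stands lowest of the three numbers; the gap to compound 2 is within the scatter, that to compound 1 is beyond it, and a 4.4-fold lower number from compound 1 to compound 3 (0.65 log units; beyond the scatter) marks the step. a 1.3-fold lower number from compound 2 to compound 3 (0.12 log units; within the scatter) shows the two hydroxyl-bearing compounds to be indistinguishable on this read-out.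

Compound 4 `CNC(=O)c1cc(C(=O)NCCO)n([C@@H](C)c2ccccc2)n1` has not yet been measured. Its change from compound 3 is a group of 3 heavy atoms (2 carbon, 1 oxygen; no ring) in place of a group of 7 heavy atoms (6 carbon, 1 oxygen; one three-membered non-aromatic ring of carbon only, one five-membered non-aromatic ring of carbon only), on an amide-type nitrogen. For the measured compounds named here, no measured step swaps a ring for a chain on this nitrogen, so only indirect bearing is available: compound 1 without a hydroxyl is high, while compound 2 and compound 3, both carrying a hydroxyl donor as compound 4 does, sit low with a 3.4-fold lower number from compound 1 to compound 2 (0.53 log units; beyond the scatter) and a 4.4-fold lower number from compound 1 to compound 3 (0.65 log units; beyond the scatter). Compound 4 is therefore expected near compound 3, with a 1.1-fold lower number from compound 3 to compound 4 (0.04 log units; within the scatter) as a step that need not exceed the scatter. The estimate for compound 4 is 55 nm/s, with a range from 20 nm/s to 130 nm/s.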

Compound 4, apparent permeability: 59 nm/s
Compound 4: the middle estimate sits 1.1-fold (0.03 log units) below what was measured; the range from low to high includes it.
By their numbers in this assay, from the lowest: compounds 4, 3 and 2 (each within the scatter of the next); then compound 1.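

On the amide-type nitrogen in this assay, the open-chain 2-hydroxyethyl group reads level with both ring-bearing hydroxyl groups, with a 1.0-fold lower number from compound 3 to compound 4 (0.01 log units; within the scatter) and a 1.4-fold lower number from compound 2 to compound 4 (0.13 log units; within the scatter), so among these three compounds the ring carbon framework makes no difference that can be read. Against the oxan-4-yl group the open chain gives a 4.6-fold lower number from compound 1 to compound 4 (0.66 log units; beyond the scatter), so the separation of compound 1 from compounds 2 and 3 also extends to a hydroxyl-bearing group with no ring. No measurement on hand accounts for this pattern.

Still open, going by these compounds, is whether the separation follows the hydroxyl itself or the oxan-4-yl group, which a 2-methoxyethyl group on this nitrogen would help to settle. Also open, on these data alone, is how a longer chain such as 3-hydroxypropyl, or an amine such as 2-aminoethyl, would read here.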